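Aryl in place of alkyl on the ring nitrogen

The source may report more compounds than this note shows. Statements on the series, on what has been measured and on what is new or still open speak of the compounds shown alone.

Compound 1 `CCCCn1ccnc1-c1cc(OC)c(OC)c(OC)c1` gives 70400 nM in a functional assay on MDA-MB-231 cells (Homo sapiens) for antiproliferative activity, read by MTT assay, with a stated time of 72 h; on this read-out lower numbers stand for stronger inhibition and higher numbers for weaker inhibition. Going by the values given here, compound 2 `CCCCCn1ccnc1-c1cc(OC)c(OC)c(OC)c1` gives 34200 nM in this assay, the lowest of the two numbers so far. The nearest number is that of compound 1, and the step between them is a 2.1-fold lower number from compound 1 to compound 2 (0.31 log units; beyond the scatter). Compound 3 `COc1cc(-c2nccn2-c2ccc(Br)cc2)cc(OC)c1OC` carries 4-bromophenyl in place of pentyl on an aromatic nitrogen. Among the compounds with values here, the only measured step puts methyl in place of hydrogen on a saturated chain carbon, a different kind of change from swapping pentyl for 4-bromophenyl on an aromatic nitrogen, so it gives little guidance on direction or size here. No shift beyond the scatter can be expected with confidence, and the estimate is centred near compound 2 with a wide range. Compound 3 is expected to give 25000 nM in this assay. The range expected for compound 3 runs from 5000 nM to 120000 nM. For compound 3 this estimate means an expected step of a 1.4-fold lower number from compound 2 to compound 3 (0.14 log units; within the scatter).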

Compound 3, half-maximal inhibitory concentration: 8400 nM
Compound 3: the middle estimate sits 3.0-fold (0.47 log units) above what was measured; measured number inside the range.
By their numbers in this assay, from the lowest: compound 3; then compound 2; then compound 1.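

On the aromatic nitrogen, in this assay, the change from a saturated chain to a ring-bearing group matters: 4-bromophenyl in place of pentyl gives a 4.1-fold lower number from compound 2 to compound 3 (0.61 log units; beyond the scatter) and remains the lowest of the three numbers. Against the butyl compound, the same substituent gives an 8.4-fold lower number from compound 1 to compound 3 (0.92 log units; beyond the scatter) and extends the earlier finding beyond alkyl groups, since this position now accepts a six-membered aromatic ring without any loss in this read-out. No evidence at hand explains the shift.

From the compounds shown here alone, whether the step belongs to the aromatic ring itself or to the bromine remains open, and plain phenyl or 4-chlorophenyl on this nitrogen would separate the two. Also open, going by these compounds, is how a longer chain, such as hexyl or octyl, would stand against 4-bromophenyl at this position.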